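The source may hold more compounds than are shown below. What is called first, only, known or untested is meant among the compounds shown, and "the series" means these compounds.

Compound 2 `COC(=O)c1ccc(OCCCCOc2ccc(C(=O)CC3CCCC3)c(C)c2C)cc1` is one of three measured compounds in an assay on HEK293 cells for positive allosteric modulation of metabotropic glutamate receptor 3 (Rattus norvegicus), read by thallium flux, with a stated time of 2.5 min (a higher number here means a larger maximal response, a lower number a smaller maximal response), where compound 2 gives 24.2%. Its nearest neighbour is compound 1 `COC(=O)c1ccc(OCCCCOc2ccc(C(=O)CC3CCCC3)c(O)c2C)cc1`, which in this assay gives 22%, and its furthest is compound 3 `Cc1ccc(C(=O)O)cc1OCCCCOc1ccc(C(=O)CC(C)C)c(O)c1C`, which gives 29.4%. All three numbers lie within the usual scatter of one another. Within the data shown here, the single measured step, a number 2.2 percentage points higher from compound 1 to compound 2 (within the scatter), concerns a different part of the shared core and says little about the change at hand. Compound 4 `Cc1c(OCCCCOc2ccc(F)c(C(=O)O)c2)ccc(C(=O)CC2CCCC2)c1C` differs from compound 2 in one place: 3-carboxy-4-fluorophenyl in place of 4-(methoxycarbonyl)phenyl on an oxygen on a saturated carbon. Among the measured compounds shown here, compound 3 also carries a carboxy group where compound 1 carries methoxycarbonyl, but compound 3 differs from compound 1 in a second place as well, so no clean step can be drawn from that pair; the two values simply show no separation beyond the scatter. Compound 4 is therefore expected to give about 26% in this assay, within 14% to 40%. That estimate means a number 1.8 percentage points higher from compound 2 to compound 4 (within the scatter), a step expected to stay within the scatter.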

Compound 4, largest response reached (reported as percent of maximum), in percent of the reference or control that the assay uses: 12.6%
For compound 4 the middle estimate is 13.4 percentage points above the measured one; measured number below the stated range.
By their numbers in this assay, from the lowest: compounds 4, 1, 2 and 3 (each within the scatter of the next, the first and the last beyond it).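

Among the compounds shown, the first single change to pass beyond the scatter in this assay is 3-carboxy-4-fluorophenyl in place of 4-(methoxycarbonyl)phenyl, which gives a number 11.6 percentage points lower from compound 2 to compound 4 (beyond the scatter) and so marks this place as one where the maximal response can shift. Among these compounds, the only earlier step, methyl in place of hydroxy on an aromatic carbon, gave a number 2.2 percentage points higher from compound 1 to compound 2 (within the scatter) and stayed within the scatter. No measurement is at hand that accounts for the lower response.

This one exchange brings in the carboxy group and the fluorine together, so the compounds shown cannot separate their contributions. From the compounds shown here alone, how a plain phenyl, an amide or a nitrile at this place would compare also remains open.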